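Aminothiazole substituent swap in a sulfonamide series

The source may hold more compounds than are shown below. What is called first, only, known or untested is meant among the compounds shown, and "the series" means these compounds.

Measured so far:
compound 1 `COc1c(NS(=O)(=O)c2ccc(F)cc2)cc(-c2ccc3nc(NC4CC4)sc3n2)cc1C(N)=O` — 41700 nM in a functional assay on U-87MG ATCC cells (Homo sapiens) for antiproliferative activity, read by MTT assay, with a stated time of 72 h; a lower number here means a stronger inhibitor, a higher number a weaker inhibitor
compound 2 `COc1c(NS(=O)(=O)c2ccc(F)cc2)cc(-c2ccc3nc(NC4CC4)sc3c2)cc1C(N)=O` — "not determined" (no result reported) in this assay

Going by the values given here, compound 1 is the only member of the series with a number. In this assay compound 1 gives 41700 nM, a weak inhibitor by any standard. Compound 2 carries the same substituents on a differently joined core, and in this assay compound 2 stands at "not determined" (no result reported), so nothing can be said about that pair.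

Compound 3 `COc1c(NS(=O)(=O)c2ccc(F)cc2)cc(-c2ccc3nc(NC(C)=O)sc3n2)cc1C(N)=O` is the next analogue to be run. It differs from compound 1 in one place: acetyl in place of cyclopropyl on a nitrogen on an aromatic ring. Among the compounds with values here, no pair of measured compounds with a single change is available, so there is no step from which to read the size or direction of this swap; compound 1 alone sets the starting level.

Expectation for compound 3: the change is small in size and sits on the same nitrogen, and with compound 1 already far from potent, no shift beyond the usual scatter is anticipated, so the step of a 1.0-fold lower number from compound 1 to compound 3 (0.02 log units; within the scatter) is estimated to be close to flat. Compound 3 is expected to give about 40000 nM in this assay, most likely between 10000 nM and 150000 nM, with a real chance that only a limit is reported.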

Compound 3, half-maximal inhibitory concentration: 21700 nM
The estimate for compound 3 lay 1.8-fold (0.27 log units) above the measured number; measured number inside the range.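

In this assay, going by these compounds alone, the first single-change step reads a 1.9-fold lower number from compound 1 to compound 3 (0.28 log units; within the scatter), so acetyl in place of cyclopropyl on this nitrogen gives no measurable difference, and the two compounds cannot be told apart. This position therefore accepts both a three-membered non-aromatic ring of carbon only and an open group with a double bond and a hydrogen-bond acceptor, without moving the read-out beyond the scatter, and compound 3 at 21700 nM remains a weak inhibitor. No measurement on hand explains this flat step.

Open, from the compounds shown here alone, is whether anything placed on this nitrogen can move the number beyond the scatter at all, for example a carboxylic acid, a morpholine or a longer alkyl chain, since two groups of similar size say little about the wider range. Also open, going by these compounds, is whether the weak level belongs to this nitrogen substituent or to other parts of the molecule, such as the fluorine on the sulfonamide ring, which a chlorine or a methoxy group could test.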